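Methoxy to isopropoxy on the shared core

The source may hold more compounds than are shown below. What is called first, only, known or untested is meant among the compounds shown, and "the series" means these compounds.

In a functional assay on A549 cells (Homo sapiens) for inhibition, read by MTT assay, with a stated time of 72 h (a lower number here means a stronger inhibitor, a higher number a weaker inhibitor), compound 1 `CC(C)(C)n1cc2c(n1)C(=O)CC1(CCN(C(=O)c3cc(-c4ccc(F)cc4)nc4ccccc34)CC1)O2` gives 5770 nM while compound 2 `CC(C)(C)n1cc2c(n1)C(=O)CC1(CCN(C(=O)c3cc(-c4ccncc4)nc4ccccc34)CC1)O2` gives 550 nM in the same read-out. Compound 3 `COc1cc(C(=O)N2CCC3(CC2)CC(=O)c2nn(C(C)(C)C)cc2O3)c2ccccc2n1` reads > 10000 nM as a limit of the assay, not a number. Compound 4 `CC(C)Oc1cc(C(=O)N2CCC3(CC2)CC(=O)c2nn(C(C)(C)C)cc2O3)c2ccccc2n1` differs from it by isopropyl in place of methyl on an oxygen on an aromatic ring in a single change: isopropyl in place of methyl on an oxygen on an aromatic ring. Among the compounds with values here, no measured step touches that group directly. The nearest steps replace the whole methoxy: an at least 18-fold higher number from compound 2 to compound 3 (1.25 log units; beyond the scatter) is large, while an at least 1.7-fold higher number from compound 1 to compound 3 (0.23 log units; that floor lies within the scatter) has a floor within the scatter. Only a modest move towards a lower number is therefore expected, and the estimated at least 1.2-fold lower number from compound 3 to compound 4 (0.09 log units; that floor lies within the scatter) may stay within the scatter. Compound 4 is expected at 8000 nM with an estimated range of 3000 nM to 20000 nM in this assay and may also reach the limit.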

Compound 4, half-maximal inhibitory concentration: > 10000 nM
Compound 4 was reported as a limit; the forecaster's own chance of this, stated with the estimate: 55%; middle value at least 1.2-fold (0.09 log units) from the limit.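

In this assay compound 4 reads > 10000 nM, which is a limit of the assay and not a number. With isopropoxy, a second alkoxy group on this aromatic carbon sits at the limit, and the step between compound 3 and compound 4 cannot be read: the limit of > 10000 nM in this assay, at which 2 of the 4 values shown sit. Replacing pyridin-4-yl with isopropoxy gives an at least 18-fold higher number from compound 2 to compound 4 (1.25 log units; beyond the scatter), while replacing 4-fluorophenyl gives an at least 1.7-fold higher number from compound 1 to compound 4 (0.23 log units; that floor lies within the scatter).

From the compounds shown here alone, whether a longer chain on that oxygen, or an amine in place of the isopropoxy, would give a readable number remains open.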